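The source may report more compounds than this note shows. Statements on the series, on what has been measured and on what is new or still open speak of the compounds shown alone.

Working notes on the series. Among the measured compounds shown here, compound 1 `O=c1[nH]c(=S)ccn1[C@@H]1O[C@H](COP(=O)(O)OP(=O)(O)OP(=O)(O)OP(=O)(O)O)[C@@H](O)[C@H]1O` gives 280 nM in an in vitro functional assay on 1321-N1 cells for agonist activity at P2Y purinoceptor 4 (Homo sapiens), read by scintillation proximity assay and inositol phosphate accumulation; on this read-out lower numbers stand for an effect already at smaller amounts and higher numbers for an effect only at larger amounts of compound; compound 2 `Nc1nc(=O)c2ncn([C@H]3C[C@H](O)[C@@H](COP(=O)(O)OP(=O)(O)OP(=O)(O)OP(=O)(O)OC[C@H]4O[C@@H](n5ccc(=O)[nH]c5=O)[C@H](O)[C@@H]4O)O3)c2[nH]1` gives 540 nM in this assay, and the two numbers lie within the scatter of each other, so compound 1 stands level with the only other measured compound. Compound 3 `O=c1ccn([C@@H]2O[C@H](COP(=O)(O)OP(=O)(O)OP(=O)(O)OP(=O)(O)O)[C@@H](O)[C@H]2O)c(=S)[nH]1` differs from compound 1 by a group of 8 heavy atoms (4 carbon, 2 nitrogen, 1 oxygen, 1 sulfur; one six-membered aromatic ring with 2 hetero atoms) in place of a group of 8 heavy atoms (4 carbon, 2 nitrogen, 1 oxygen, 1 sulfur; one six-membered aromatic ring with 2 hetero atoms), on a saturated ring carbon. For the measured compounds named here, no measured pair shows the size of such a rearrangement, so the step from compound 1 to compound 3 is expected to be small, at most modest toward smaller amounts, a 1.9-fold lower number from compound 1 to compound 3 (0.27 log units; within the scatter). Compound 3 is therefore estimated at 150 nM, between 40 nM and 600 nM.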

Compound 3, half-maximal effective concentration: 5520 nM
Compound 3: middle estimate off by 37-fold (1.57 log units), on the low side, and the stated range ends below it.
By their numbers in this assay, from the lowest: compounds 1 and 2 (each within the scatter of the next); then compound 3.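

In this assay, rearranging the atoms inside the group on the saturated ring carbon gives a 20-fold higher number from compound 1 to compound 3 (1.29 log units; beyond the scatter) even though the counts of atoms, hydrogen-bond donors and acceptors and the net charge stay the same. At this position the read-out therefore depends on how the six-membered aromatic ring group is joined, not only on what it contains. Nothing available explains the size of this step. On these data alone, it remains open whether an amine in place of the sulfur would leave the number near that of compound 1 or near that of compound 3.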